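Chloro for ethyl on a urea in a whole-plant assay

A few compounds are considered here, and "the series" means these few. Any claim that something is new, unique, unknown or untested is made for them only; others in the source may bear on it.

The series is built around a urea that joins a substituted aromatic ring to a one-carbon-branched benzylic amine. Compound 1 `CCc1cccc(NC(=O)N[C@H](C)c2ccccc2)c1` and compound 2 `CCc1cccc(NC(=O)N[C@@H](C)c2ccccc2)c1` share every atom and bond and differ only in configuration as drawn, and in an ADME assay on the whole organism with Oryza sativa as the target, tested at 10 uM (a lower number here means a stronger effect, a higher number a weaker effect of the compound at the concentration tested), compound 1 gives 36% while compound 2 gives 86%. This single measured step, a number 50 percentage points higher from compound 1 to compound 2 (beyond the scatter), rests on (the fact that compounds 1 and 2 differ only in the configuration as drawn). Compound 3 `CCCCCCc1ccc(NC(=O)N[C@H](C)c2ccccc2)cc1`, with a hexyl chain in place of the ethyl and on a different ring position, gives 101% in this assay. Compound 2 therefore stands second highest of the three numbers: beyond the scatter below compound 3 and far beyond the scatter above compound 1.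

Compound 4 `C[C@H](NC(=O)Nc1cccc(Cl)c1)c1ccccc1` keeps the configuration of compound 2 and changes one group on the aromatic ring: chloro in place of ethyl on an aromatic carbon. Within the data shown here, no measured step describes such an exchange; the only step in hand, from compound 1 to compound 2, concerns configuration and so does not bear on it. With nothing to point either way, the change from compound 2 to compound 4 is expected to give a step within the scatter, a number 1 percentage points lower from compound 2 to compound 4 (within the scatter). Compound 4 is thus estimated at 85% in this assay, between 60% and 105%.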

Compound 4, a percentage reported as activity, at one concentration (the size of the read-out at that concentration, not a potency): 103%
For compound 4 the middle estimate is 18 percentage points below the measured one; low and high end bracket the measured number.
By their numbers in this assay, from the lowest: compound 1; then compound 2; then compounds 3 and 4 (each within the scatter of the next).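

In this assay, among these compounds, chloro in place of ethyl on an aromatic carbon, meta to a large group, gives a number 17 percentage points higher from compound 2 to compound 4 (beyond the scatter) and so is not a neutral exchange: the group held at this position matters, which the earlier compounds could not show, since their only one-place step concerned configuration. The step runs towards a weaker effect at the concentration tested, and it is smaller than a number 50 percentage points higher from compound 1 to compound 2 (beyond the scatter), so in this small set both the ring group and the configuration move the number, the configuration by more. Nothing available bears on why this exchange moves the number as it does.

As far as these compounds go, the step was read on the configuration of compound 2 alone, so it remains open whether the same exchange would move the number in the same way on the configuration of compound 1, which gives 36% and thus has an effect left to lose. Also open, from the compounds shown here alone, is how a methoxy group, an amine or a carboxylic acid on this aromatic carbon would compare with ethyl and chloro.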